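This account rests on a few compounds, and the source may have more. Where it says the series, first, only, none or still open, it means among the compounds named here.

In an assay on Sf9 cells for inhibition of Amine oxidase [flavin-containing] A (Homo sapiens), with stated times of 15 min and 60 min (on this read-out lower numbers stand for stronger inhibition and higher numbers for weaker inhibition), compound 1 `NC(=O)C1CCN1Cc1ccc(OCc2cccc(F)c2)cc1` gives 18000 nM, the highest of the three numbers seen, and so the weakest inhibitor of the set. Compound 2 `NC(=O)[C@@H]1CCN1Cc1ccc(OCc2cccc(F)c2)cc1Cl` gives 2130 nM and compound 3 `Cc1cc(OCc2cccc(F)c2)ccc1CN1CC[C@H]1C(N)=O` gives 8650 nM; both sit well below compound 1. For the measured compounds named here, the only single-change step among the measured compounds, a 4.1-fold higher number from compound 2 to compound 3 (0.61 log units; beyond the scatter), concerns a substituent on an aromatic carbon and says nothing about the ring attached to the saturated chain carbon bound to an aromatic carbon.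

Compound 4 `NC(=O)[C@@H]1CCCN1Cc1ccc(OCc2cccc(F)c2)cc1` has not yet been measured. It differs from compound 1 by 2-carbamoylpyrrolidin-1-yl in place of 2-carbamoylazetidin-1-yl on a saturated chain carbon bound to an aromatic carbon. The amide and the ring nitrogen are kept, while the four-membered ring gives way to a five-membered one. Going by the values given here, none of the measured steps touches this part of the molecule, so there is no direct guide to the size or direction of the change. Without such a guide the expectation is for a number near that of compound 1, with the step from compound 1 to compound 4 estimated as a 1.2-fold lower number from compound 1 to compound 4 (0.08 log units; within the scatter), not clearly beyond the scatter. Compound 4 is therefore expected to give about 15000 nM in this assay, within a wide range from 4000 nM to 50000 nM.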

Compound 4, half-maximal inhibitory concentration: 34200 nM
Beside the measured number, compound 4's estimate is 2.3-fold (0.36 log units) below it, within the range that was stated.
By their numbers in this assay, from the lowest: compound 2; then compound 3; then compounds 1 and 4 (each within the scatter of the next).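

In this assay, 2-carbamoylpyrrolidin-1-yl in place of 2-carbamoylazetidin-1-yl on a saturated chain carbon bound to an aromatic carbon gives a 1.9-fold higher number from compound 1 to compound 4 (0.28 log units; within the scatter). For the compounds shown here, this is the first direct look at this position, and it shows that going from the four-membered ring to the five-membered ring, with the amide and the ring nitrogen kept, does not separate the two compounds in this read-out. The comparison carries one caveat, since the entering group has a defined stereocentre and the group it replaces, as drawn in compound 1, has none, and nothing at hand bears on why the two compounds fall so close together.

On these data alone, it remains open whether a larger ring, such as the six-membered piperidine carrying the same amide, or a carboxylic acid or a nitrile in place of the amide, would move the number beyond the scatter. Also unsettled is whether the chloro or methyl group on the aromatic ring, which separates compound 2 from compound 3, would have a step of similar size on the shared core of compound 4.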